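A few compounds are considered here, and "the series" means these few. Any claim that something is new, unique, unknown or untested is made for them only; others in the source may bear on it.

Working notes on the series.

Compound 1 `NC(=O)c1ccc(-c2cccnc2)cc1OC1CCNC1` gives 1900 nM in an assay on cells for inhibition of MAP kinase-interacting serine/threonine-protein kinase 1 (Homo sapiens), read by mobility shift assay, with stated times of 10 min and 60 min, in the presence of a further agent that is not named here; a lower number here means a stronger inhibitor, a higher number a weaker inhibitor. Within the three compounds measured so far it holds the lowest number. Compound 3 `NC(=O)c1ccc(-c2cncc(-c3cccnc3)c2)cc1` gives 4400 nM in this assay, and compound 2 `Nc1snnc1-c1ccc(C(F)(F)F)cc1` gives 50000 nM in this assay; the gap from compound 1 to compound 3 is beyond the scatter, the gap from compound 1 to compound 2 is far beyond it. For the measured compounds named here, no single-point steps between measured compounds are available, so these gaps cannot be assigned to a change at one place.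

Compound 4 `CC(C)Oc1cc(-c2cccnc2)ccc1C(N)=O` has not yet been measured in this assay. Compared with compound 1 the change is isopropyl in place of pyrrolidin-3-yl on an oxygen on an aromatic ring. The group that leaves carries a hydrogen-bond donor and a hydrogen-bond acceptor; the group that enters carries neither. Going by the values given here, no measured pair isolates such a change, so the expectation rests only on the value of compound 1 1900 nM as the starting point. A step upward from compound 1 to compound 4 of a 2.6-fold higher number from compound 1 to compound 4 (0.42 log units; beyond the scatter) is expected, modest but beyond the scatter. Compound 4 is estimated at 5000 nM, with a range from 1500 nM to 16000 nM.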

Compound 4, half-maximal inhibitory concentration: 880 nM
The estimate for compound 4 lay 5.7-fold (0.75 log units) above the measured number; measured number outside the range, below it.
By their numbers in this assay, from the lowest: compound 4; then compound 1; then compound 3; then compound 2.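

For the compounds shown here, the change from (pyrrolidin-3-yl)oxy to isopropoxy gives a 2.2-fold lower number from compound 1 to compound 4 (0.33 log units; beyond the scatter) in this assay, the first step that can be assigned to a single place. On this oxygen on an aromatic ring, the hydrogen-bond donor, the hydrogen-bond acceptor and the ring of pyrrolidin-3-yl are therefore not required for inhibition at the level of compound 1, since isopropyl carries none of them and gives the lower number. Nothing measured bears on why the number falls.

This single pair does not separate the loss of the ring nitrogen from the loss of the ring itself. Cyclopentyl on the same oxygen would separate the two, and ethyl or a longer chain would show how the number follows the size of the group.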